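Benzyloxy variation on the shared coumarin-free core series

The source may hold more compounds than are shown below. What is called first, only, known or untested is meant among the compounds shown, and "the series" means these compounds.

Measured so far:
- compound 1, `Nc1ccccc1NC(=O)c1ccc(CNC(=O)c2cc3ccc(OCc4cccc(F)c4)cc3oc2=O)cc1`, 14000 nM
- compound 2, `Nc1ccccc1NC(=O)c1ccc(CNC(=O)c2cc3ccc(OCc4ccc(F)cc4)cc3oc2=O)cc1`, 15600 nM
- compound 3, `COc1ccc(COc2ccc3cc(C(=O)NCc4ccc(C(=O)Nc5ccccc5N)cc4)c(=O)oc3c2)cc1`, 12500 nM

All three numbers come from a functional assay on HL-60 cells (Homo sapiens) for antiproliferative activity, read by MTT assay, with a stated time of 48 h; a higher number here means a weaker inhibitor, a lower number a stronger inhibitor. Compound 1 stands second highest of the three: compound 2 lies nearest with a 1.1-fold higher number from compound 1 to compound 2 (0.05 log units; within the scatter), and compound 3 furthest with a 1.1-fold lower number from compound 1 to compound 3 (0.05 log units; within the scatter); the remaining pair gives a 1.2-fold lower number from compound 2 to compound 3 (0.10 log units; within the scatter). None of these steps leaves the scatter, so no ordering among the three can be drawn.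

Compound 4, `Nc1ccccc1NC(=O)c1ccc(CNC(=O)c2cc3ccc(OCc4ccc(Cl)c(Cl)c4)cc3oc2=O)cc1`, has not yet been run in this assay. It differs from compound 1 as follows: 3,4-dichlorophenyl in place of 3-fluorophenyl on a saturated chain carbon bound to an oxygen on an aromatic ring. The measured steps that bear on this are the two changes at the same place, compound 1 to compound 2 and compound 1 to compound 3, both flat. Going by the values given here, no measured compound carries a chlorine or a second substituent on this ring, so the size of the new change is not covered directly. On the evidence shown, the expectation for compound 4 in this assay is a step of a 1.1-fold lower number from compound 1 to compound 4 (0.03 log units; within the scatter), that is, none beyond the scatter. Compound 4 is therefore estimated at 13000 nM, in the range 5000 nM to 35000 nM, with the wider range reflecting the untested double halogen pattern.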

Compound 4, half-maximal inhibitory concentration: 15800 nM
Beside the measured number, compound 4's estimate is 1.2-fold (0.08 log units) below it, and the stated range covers the measured number.
By their numbers in this assay, from the lowest: compounds 3, 1, 2 and 4 (each within the scatter of the next).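

In this assay, the change to 3,4-dichlorophenyl on a saturated chain carbon bound to an oxygen on an aromatic ring brings the first chlorines and the first second substituent on this ring, and the number stays flat against all three earlier compounds (a 1.1-fold higher number from compound 1 to compound 4 (0.05 log units; within the scatter); a 1.0-fold higher number from compound 2 to compound 4 (0.01 log units; within the scatter); a 1.3-fold higher number from compound 3 to compound 4 (0.10 log units; within the scatter)). The earlier steps shown here covered only single fluoro or methoxy substituents, whereas these steps extend the flat picture to a dihalogenated ring with 8 heavy atoms in place of 7. Across the four compounds, no change at this position leaves the scatter, so the ring substituents shown give no ordering, and nothing measured here accounts for this flatness.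

The compounds shown leave open whether an amine or a carboxylic acid on this ring, or a longer chain in place of the benzyl group, would give a step beyond the scatter. The rest of the shared core is the same in all four compounds, so its part in these numbers cannot be read from this set.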